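Replacing the carbamoyl of compound 2 with aminomethyl

A few compounds are considered here, and "the series" means these few. Any claim that something is new, unique, unknown or untested is made for them only; others in the source may bear on it.

Measured so far:
- compound 1, `Nc1ccc(O)c2ccncc12`: 19000 nM
- compound 2, `NC(=O)c1ccc(O)c2ccccc12`: 430000 nM
- compound 3, `CCCCCCCCCC(=O)Nc1ccc(O)c2ccccc12`: 18000 nM

All three were measured in a functional assay, with a stated time of 15 min; a higher number here means that more compound is needed for the effect, a lower number that less compound is needed. Compound 2 stands at the top of the three numbers: compound 1 and compound 3 give values far below it, and both gaps are beyond the usual scatter of repeated measurements. So among the three, compound 2 is the one that needs the most material to reach the half-maximal effect.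

The next compound, compound 4, `NCc1ccc(O)c2ccccc12`, has not been measured. It differs from compound 2 in a single place: aminomethyl in place of carbamoyl on an aromatic carbon. Everything else in the shared core, including the hydroxy group, is kept.

Within the data shown here, no pair of measured compounds differs in just this way, so no measured step shows what this exchange does. What can be said is that compound 1, which carries a nitrogen directly on the core rather than a carbamoyl, gives 19000 nM, well below compound 2. On that basis a sizeable step downward in this assay, beyond the scatter, is expected. Compound 4 is estimated at 40000 nM, within 8000 nM to 200000 nM, which would mean an expected step of an 11-fold lower number from compound 2 to compound 4 (1.03 log units; beyond the scatter).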

Compound 4, half-maximal effective concentration: 260000 nM
The estimate for compound 4 lay 6.5-fold (0.81 log units) below the measured number; the whole stated range lies below it.
By their numbers in this assay, from the lowest: compounds 3 and 1 (each within the scatter of the next); then compounds 4 and 2 (each within the scatter of the next).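

Among these compounds, this is the first one-place step measured at this position: in this assay, putting aminomethyl in place of carbamoyl on the aromatic carbon para to a hydroxy group gives a 1.7-fold lower number from compound 2 to compound 4 (0.22 log units; within the scatter). The exchange takes away a heavy atom and the double bond outside the aromatic rings, while the count of hydrogen-bond donors and acceptors stays the same, and the two numbers still cannot be told apart from repeat scatter, so in this pair the carbonyl oxygen of carbamoyl can go without a readable step. Nothing measured here says why these two groups read alike, and this one pair sets no rule for other groups at this position.

The compounds shown leave open whether other groups on this aromatic carbon, such as a carboxylic acid or a dimethylaminomethyl group, would also stay within the scatter of compound 2 or move clearly away from it. They also leave open how much the hydroxy group contributes to these numbers, which a methoxy group in its place on compound 4 would begin to address.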